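This account rests on a few compounds, and the source may have more. Where it says the series, first, only, none or still open, it means among the compounds named here.

Compound 1, `Cc1cc(=O)n(-c2ccc(F)c(F)c2)nc1C(=O)Nc1ccc(Oc2ncnc3ccsc23)cc1`, gives 9230 nM in a functional assay on HepG2 cells (Homo sapiens) for cytotoxicity, read by MTT assay, with a stated time of 72 h; a lower number here means a stronger inhibitor, a higher number a weaker inhibitor. Compound 2, `Cc1ccc(-n2nc(C(=O)Nc3ccc(Oc4ncnc5ccsc45)c(F)c3)c(C)cc2=O)cc1`, gives 17300 nM in this assay.

Within the data shown here, compound 2 holds the higher of the two numbers, but its only neighbour, compound 1, sits within the scatter of it, so no order between the two can be claimed. Compound 3, `Cc1cc(=O)n(-c2ccc(F)c(F)c2)nc1C(=O)Nc1ccc(Oc2ncnc3ccsc23)c(F)c1`, differs from compound 2 by 3,4-difluorophenyl in place of 4-methylphenyl on an aromatic nitrogen. Among the measured compounds shown here, no pair of measured compounds isolates this change, so the step from compound 2 to compound 3 in this assay is expected to stay within the scatter, with no clear direction, as a 1.4-fold lower number from compound 2 to compound 3 (0.16 log units; within the scatter). Compound 3 is therefore estimated at 12000 nM, between 4500 nM and 32000 nM.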

Compound 3, half-maximal inhibitory concentration: 6930 nM
Estimate against measurement, compound 3: 1.7-fold (0.24 log units) above, and the stated range covers the measured number.
By their numbers in this assay, from the lowest: compounds 3, 1 and 2 (each within the scatter of the next, the first and the last beyond it).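

In this assay, 3,4-difluorophenyl in place of 4-methylphenyl on the aromatic nitrogen gives a 2.5-fold lower number from compound 2 to compound 3 (0.40 log units; beyond the scatter), a modest step and the only one at this position that can be read. Fluoro in place of hydrogen on an aromatic carbon gives a 1.3-fold lower number from compound 1 to compound 3 (0.12 log units; within the scatter), so this pair shows no difference from that change. Nothing at hand gives a reason for either step. Going by these compounds, how phenyl, 4-chlorophenyl or 4-methoxyphenyl would read on that nitrogen remains open. Also open, on these data alone, is whether the step there holds with hydrogen in place of that aromatic fluoro.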